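The source may hold more compounds than are shown below. What is called first, only, known or untested is meant among the compounds shown, and "the series" means these compounds.

Measured so far:
- compound 1, `CC(C)(C)c1csc(Nc2cccc3ccccc23)n1`: 80 nM
- compound 2, `CC(C)(C)Cc1csc(Nc2cccc3ccccc23)n1`: 220 nM
- compound 3, `CC(C)(C)c1ccc(-c2csc(Nc3cccc4ccccc34)n2)cc1`: 900 nM

All three share one core and differ only in the group on its five-membered ring. In an assay on CCRF-CEM cells for displacement of a labelled ligand from C-C chemokine receptor type 4 (Homo sapiens) (a higher number here means a weaker inhibitor, a lower number a stronger inhibitor), compound 1 gives the lowest of the three numbers; compound 2 is nearest, compound 3 furthest, and both gaps lie beyond the scatter.

Compound 4, `NCc1csc(Nc2cccc3ccccc23)n1`, has not yet been measured. It differs from compound 1 in one place: aminomethyl in place of tert-butyl on an aromatic carbon. Compound 4 thus loses the four carbon atoms of tert-butyl and gains a group with one hydrogen-bond donor and one hydrogen-bond acceptor, at the same position on the ring.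

Going by the values given here, only one measured step bears on this position: a 2.8-fold higher number from compound 1 to compound 2 (0.44 log units; beyond the scatter), a modest change from one carbon group to a larger carbon group. Compound 3, which carries a still larger carbon group, gives a number far above that of compound 1. Among the compounds with values here, no measured compound carries a group with a hydrogen-bond donor here, so the data give no direct guide, and a change of this kind is larger than any already seen.

A clear rise is therefore expected in this assay, and the step from compound 1 to compound 4 is estimated at a 19-fold higher number from compound 1 to compound 4 (1.27 log units; beyond the scatter). Compound 4 is expected to give about 1500 nM, with a range from 300 nM to 8000 nM.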

Compound 4, half-maximal inhibitory concentration: > 25000 nM
Compound 4: only a limit was reported; the forecaster's own chance of this, stated with the estimate: 20%; middle value at least 16-fold (1.22 log units) away from the limit.
By their numbers in this assay, from the lowest: compound 1; then compound 2; then compound 3. At a limit, above all of these: compound 4.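

In this assay, compound 4 gives no exact number, only a limit: the limit of > 25000 nM in this assay, at which 1 of the 4 values shown sits. Replacing tert-butyl with aminomethyl produces a large change, an at least 310-fold higher number from compound 1 to compound 4 (2.49 log units; beyond the scatter), and measured from the neopentyl group the change is also large, an at least 110-fold higher number from compound 2 to compound 4 (2.05 log units; beyond the scatter). Compounds 1, 2 and 3 carry only carbon groups at this position and all give measured numbers, even with the large group of compound 3, so these four compounds show that a smaller group containing nitrogen can cost far more here than a bigger carbon group does.

These compounds cannot separate the effect of adding the nitrogen from the effect of losing the carbon atoms of tert-butyl, and a small carbon group such as methyl or ethyl would be needed to tell the two apart. As far as these compounds go, it also remains open whether aminomethyl is a special case or whether other groups at this position behave in the same way, such as hydroxymethyl, a methyl ether, an amide, or an amine on a longer chain.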